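Pyridyl to thienyl: expected loss of the cytotoxicity ceiling

The compounds below may be only part of what the source reports. "The series", "measured", "known", "first", "only" and "open" are said of these compounds alone.

Compound 3 `COc1cc(CC(O)c2ccc(-c3ccncc3)cc2)c([N+](=O)[O-])cc1OC` gives in an ADME assay on HeLa Rh cells (Homo sapiens) for cytotoxicity, read by microscopy (a higher number here means that more compound is tolerated, a lower number that less compound is tolerated), only a limit, > 263000 nM, and no number. The other two members of the series sit well inside the measurable range: compound 1 `COc1cc(CC(O)c2ccc(-c3ccc(C#N)cc3)cc2)c([N+](=O)[O-])cc1OC` gives 4700 nM and compound 2 `COc1cc(CC(O)c2ccc(-c3cccc(F)c3)cc2)c([N+](=O)[O-])cc1OC` gives 7400 nM, and the step of a 1.6-fold higher number from compound 1 to compound 2 (0.20 log units; within the scatter) stays within the scatter. The steps into the pyridyl compound are large in both cases: an at least 55-fold higher number from compound 1 to compound 3 (1.74 log units; beyond the scatter) and an at least 35-fold higher number from compound 2 to compound 3 (1.55 log units; beyond the scatter), each ending at the limit of > 263000 nM in this assay, at which 1 of the 3 values shown sits.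

Compound 4 `COc1cc(CC(O)c2ccc(-c3cccs3)cc2)c([N+](=O)[O-])cc1OC` changes the same position the other way, (thiophen-2-yl in place of pyridin-4-yl on an aromatic carbon). Among the measured compounds shown here, no step from a pyridyl to a thienyl group has been measured here; the only steps that bear on it are those leaving a carbocyclic aryl for the pyridyl ring, both large, so their reverse suggests a return toward the numbers of compound 1 and compound 2, although a thienyl group is not a phenyl group. Compound 4 is therefore expected to step an at least 26-fold lower number from compound 3 to compound 4 (1.41 log units; beyond the scatter), to an estimated 10000 nM, with a range from 3000 nM to 60000 nM.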

Compound 4, half-maximal cytotoxic concentration: 11000 nM
For compound 4 the middle estimate is 1.1-fold (0.04 log units) below the measured one, and the stated range covers the measured number.
By their numbers in this assay, from the lowest: compounds 1, 2 and 4 (each within the scatter of the next, the first and the last beyond it). At a limit, above all of these: compound 3.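

In this assay, the high limit of the pyridin-4-yl compound does not carry over to another ring with a hetero atom: an at least 23-fold lower number from compound 3 to compound 4 (1.37 log units; beyond the scatter), so a hetero atom in the ring at this position is not enough in itself. Thiophen-2-yl instead falls in the measurable range with the carbocyclic groups, with a 1.5-fold higher number from compound 2 to compound 4 (0.17 log units; within the scatter) and a 2.3-fold higher number from compound 1 to compound 4 (0.37 log units; beyond the scatter). Of the four groups, compound 3 alone remains at a limit and gives no number: the limit of > 263000 nM in this assay, at which 1 of the 4 values shown sits.

The compounds shown leave open whether an amine or a carboxylic acid at this position would also reach that limit, or whether pyridin-4-yl stands alone. Going by these compounds, the true size of the steps involving compound 3 also stays open, as each one ends at a limit.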